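Compound 4: From Pyridin-4-yl to 3,4-Difluorophenyl

The source may report more compounds than this note shows. Statements on the series, on what has been measured and on what is new or still open speak of the compounds shown alone.

Measured compounds:
compound 1, `Nc1scc(CN2CCN(c3ccc(Cl)cc3Cl)CC2)c1C(=O)c1ccc(Cl)cc1`, 2%
compound 2, `Nc1scc(CN2CCN(c3ccc(OC(F)(F)F)cc3)CC2)c1C(=O)c1ccc(Cl)cc1`, 0%
compound 3, `Nc1scc(CN2CCN(c3ccncc3)CC2)c1C(=O)c1ccc(Cl)cc1`, -4%

In a functional assay on CHO cells with adenosine receptor A1 (Homo sapiens) as the target, read by cAMP accumulation and immunoassay, with a stated time of 6 min, tested at 0.01 uM (a lower number here means a stronger effect, a higher number a weaker effect of the compound at the concentration tested), compound 1 gives 2%, compound 2 gives 0% and compound 3 gives -4%. Compound 3 carries the smallest number of the three, yet the steps leading to it, a number 6 percentage points lower from compound 1 to compound 3 (within the scatter) and a number 4 percentage points lower from compound 2 to compound 3 (within the scatter), do not rise above the scatter, so the three compounds are effectively indistinguishable in this assay.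

Compound 4, `Nc1scc(CN2CCN(c3ccc(F)c(F)c3)CC2)c1C(=O)c1ccc(Cl)cc1`, differs from compound 3 in one place: 3,4-difluorophenyl in place of pyridin-4-yl on an amine nitrogen in a ring. Every measured step concerns exactly this position, where one aryl group on the ring nitrogen replaces another. Those steps were a number 2 percentage points lower from compound 1 to compound 2 (within the scatter), a number 6 percentage points lower from compound 1 to compound 3 (within the scatter) and a number 4 percentage points lower from compound 2 to compound 3 (within the scatter), all within the scatter. On that basis no step beyond the scatter is expected for the change to compound 4, and the expected step is a number 4 percentage points higher from compound 3 to compound 4 (within the scatter). Compound 4 is therefore estimated to give 0% in this assay, with a range from -10% to 10%.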

Compound 4, a percentage reported as activity, at one concentration (the size of the read-out at that concentration, not a potency): -3.2%
Estimate against measurement, compound 4: 3.2 percentage points above; measured number inside the range.
By their numbers in this assay, from the lowest: compounds 3, 4, 2 and 1 (each within the scatter of the next).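

In this assay, 3,4-difluorophenyl in place of pyridin-4-yl gives a number 0.8 percentage points higher from compound 3 to compound 4 (within the scatter), while the same group gives a number 3.2 percentage points lower from compound 2 to compound 4 (within the scatter) and a number 5.2 percentage points lower from compound 1 to compound 4 (within the scatter). This position therefore now holds a third carbon-only aryl group, one bearing two fluorines, and none of the four aryl groups is set apart from another by a step beyond the scatter. Nothing shown accounts for this flat result.

The compounds shown leave open whether a carboxylic acid, an amine or a plain alkyl chain in place of the aryl group on the ring nitrogen would give a step beyond the scatter. They also leave open how these compounds differ in potency, as the read-out comes from one concentration.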